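Amide capping of the chain acid in the pyrazolyl-furan carboxamide series

The compounds below may be only part of what the source reports. "The series", "measured", "known", "first", "only" and "open" are said of these compounds alone.

Measured compounds in an assay for inhibition of RAC-alpha serine/threonine-protein kinase (Homo sapiens), read by HTRF, with a stated time of 1 h; on this read-out higher numbers stand for weaker inhibition and lower numbers for stronger inhibition:
compound 1 `Cn1ncc(Cl)c1-c1cc(C(=O)N[C@@H]2CN[C@H](CCO)C[C@H]2c2ccc(F)c(F)c2)oc1Cl` gives 0.98 nM
compound 2 `Cn1ncc(Cl)c1-c1cc(C(=O)N[C@@H]2CN[C@H](CC(=O)O)C[C@H]2c2ccc(Cl)c(Cl)c2)oc1Cl` gives 1.94 nM
compound 3 `CNC(=O)C[C@@H]1C[C@@H](c2ccc(F)c(F)c2)[C@H](NC(=O)c2cc(-c3c(Cl)cnn3C)c(Cl)o2)CN1` gives 1.37 nM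

Compound 2 gives the highest of the three numbers, but its gaps to compound 3 and to compound 1 are both within the scatter, so the three compounds read as equivalent on this assay.

Compound 4 `Cn1ncc(Cl)c1-c1cc(C(=O)N[C@@H]2CN[C@H](CC(=O)NCC(O)CO)C[C@H]2c2ccc(Cl)c(Cl)c2)oc1Cl` is not yet measured. It differs from compound 2 in one place: (2,3-dihydroxypropyl)amino in place of hydroxy on a carbonyl carbon.

Among the compounds with values here, the only measured step that touches the same chain is the one from a hydroxymethyl to a methylcarbamoyl, which gave a 1.4-fold higher number from compound 1 to compound 3 (0.15 log units; within the scatter). That step converts a neutral chain terminus into an amide and left the number where it was. Within the data shown here, compound 4 instead converts the carboxy of compound 2 into a (2,3-dihydroxypropyl)carbamoyl; no measured pair covers that exact change, so the expectation rests on the flat result of compound 1 to compound 3 and on the flat spread across compounds 1 to 3. A step of no more than the scatter is expected in this assay, with no preferred direction.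

Compound 4 is therefore estimated at 2 nM, with a range of 0.9 nM to 4.5 nM, which means an expected step of a 1.0-fold higher number from compound 2 to compound 4 (0.01 log units; within the scatter).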

Compound 4, half-maximal inhibitory concentration: 3.13 nM
The estimate for compound 4 lay 1.6-fold (0.19 log units) below the measured number; low and high end bracket the measured number.
By their numbers in this assay, from the lowest: compounds 1, 3, 2 and 4 (each within the scatter of the next, the first and the last beyond it).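

In this assay, putting (2,3-dihydroxypropyl)amino in place of hydroxy on the carbonyl carbon gives a 1.6-fold higher number from compound 2 to compound 4 (0.21 log units; within the scatter), so the carboxy group can be exchanged for a much larger amide without a step beyond the scatter. The earlier compounds shown here covered only a small exchange on this chain, a 1.4-fold higher number from compound 1 to compound 3 (0.15 log units; within the scatter), whereas this change brings in 6 heavy atoms and 3 hydrogen-bond donors in place of a single hydroxy. No measurement on hand accounts for this flat result.

The compounds shown leave open how dimethylamino, morpholine or a longer hydroxyalkylamino chain would read on this carbonyl carbon, and whether either hydroxy of the (2,3-dihydroxypropyl)amino matters to the number. Also open, on these data alone, is whether the same change reads alike with the difluorophenyl group of compound 3 in place of the dichlorophenyl group.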